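The source may report more compounds than this note shows. Statements on the series, on what has been measured and on what is new or still open speak of the compounds shown alone.

Measured compounds in a functional assay on NCI-H1975 cells (Homo sapiens) for inhibition, read by MTT assay, with a stated time of 72 h; a higher number here means a weaker inhibitor, a lower number a stronger inhibitor: compound 1 `C=CC(=O)Nc1cccc(NC(=O)CSc2nc(Nc3cccc(Br)c3)c3ccccc3n2)c1` gives 12100 nM; compound 2 `C=CC(=O)Nc1cccc(NC(=O)CSc2nc(Nc3cccc([N+](=O)[O-])c3)c3ccccc3n2)c1` gives 22600 nM; compound 3 `C=CC(=O)Nc1cccc(NC(=O)CSc2nc(Nc3cccc(OC)c3)c3ccccc3n2)c1` gives 7940 nM.

Compound 3 has the lowest of the three numbers in this assay. Its nearest neighbour is compound 1, which stands a 1.5-fold lower number from compound 1 to compound 3 (0.18 log units; within the scatter) away, so the two cannot be ordered. Compound 2 is further off, a 2.8-fold lower number from compound 2 to compound 3 (0.45 log units; beyond the scatter), a modest but real gap. Compound 1 to compound 2 shows a 1.9-fold higher number from compound 1 to compound 2 (0.27 log units; within the scatter).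

Compound 4 `C=CC(=O)Nc1cccc(NC(=O)CSc2nc(Nc3ccc(F)cc3)c3ccccc3n2)c1` is not yet measured. It differs from compound 3 as 4-fluorophenyl in place of 3-methoxyphenyl on a nitrogen on an aromatic ring. The measured steps that touch the same place are those from compound 1 to compound 3 and from compound 2 to compound 3, both exchanging one group on that phenyl ring; one stayed within the scatter, the other was modest. Within the data shown here, no measured compound carries a fluoro group, and none carries its substituent in the 4-position, so the present change reaches beyond what the three steps cover. Given that the largest step seen in this series was only modest, a small step is expected, most likely within the scatter and, if anything, toward a higher number. Compound 4 is therefore estimated at 10000 nM, between 4000 nM and 25000 nM, which would mean an expected step of a 1.3-fold higher number from compound 3 to compound 4 (0.10 log units; within the scatter).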

Compound 4, half-maximal inhibitory concentration: 4430 nM
Compound 4: middle estimate off by 2.3-fold (0.35 log units), on the high side; measured number inside the range.
By their numbers in this assay, from the lowest: compounds 4, 3, 1 and 2 (each within the scatter of the next, the first and the last beyond it).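

In this assay, the exchange to 4-fluorophenyl on a nitrogen on an aromatic ring gives a 1.8-fold lower number from compound 3 to compound 4 (0.25 log units; within the scatter), which leaves that pair unordered, while the same group also gives a 2.7-fold lower number from compound 1 to compound 4 (0.44 log units; beyond the scatter) and a 5.1-fold lower number from compound 2 to compound 4 (0.71 log units; beyond the scatter), and both of these gaps are modest but real. The spread seen at this place therefore grows past the largest earlier step, a 2.8-fold lower number from compound 2 to compound 3 (0.45 log units; beyond the scatter), and a change of both the substituent and its place on the ring costs no activity against any of the three earlier compounds. No measurement here explains why the exchange reads this way.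

The 4-fluorophenyl group differs from the earlier groups in both its substituent and that substituent's place on the ring, so the compounds shown cannot separate the two contributions, and 3-fluorophenyl and 4-methoxyphenyl would be the direct tests. Going by these compounds, how this place responds to an amine or a carboxylic acid on the ring, or to a plain phenyl, also stays open, as does whether the small spread holds for a longer chain on that nitrogen.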